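This account rests on a few compounds, and the source may have more. Where it says the series, first, only, none or still open, it means among the compounds named here.

Measured compounds:
compound 1 `COc1ccc(-c2nc(SCC(=O)c3sc(-c4ccccc4)nc3C)[nH]c(=O)c2C#N)cc1OC` gives 15300 nM in a functional assay on U-87MG ATCC cells for antiproliferative activity against U-87 MG (Homo sapiens), read by MTT assay, with a stated time of 48 h; a higher number here means a weaker inhibitor, a lower number a stronger inhibitor;
compound 2 `COc1ccc(-c2nc(SCC(=O)c3sc(-c4ccc(Cl)cc4)nc3C)[nH]c(=O)c2C#N)cc1OC` gives 38600 nM in this assay;
compound 3 `Cc1nc(-c2ccccc2)sc1C(=O)CSc1nc(-c2ccc(Cl)cc2)c(C#N)c(=O)[nH]1` gives 43400 nM in this assay.

Compound 2 differs from compound 1 by chloro in place of hydrogen on an aromatic carbon, and this brought a 2.5-fold higher number from compound 1 to compound 2 (0.40 log units; beyond the scatter). The cores of compound 1 and compound 3 differ by 4-chlorophenyl in place of 3,4-dimethoxyphenyl on an aromatic carbon, which brought a 2.8-fold higher number from compound 1 to compound 3 (0.45 log units; beyond the scatter). Compound 2 and compound 3 lie within the scatter of each other.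

Compound 4 `Cc1nc(-c2ccc(Cl)cc2)sc1C(=O)CSc1nc(-c2ccc(Cl)cc2)c(C#N)c(=O)[nH]1` is not yet measured. It differs from compound 3 by chloro in place of hydrogen on an aromatic carbon, the same change as made from compound 1 to compound 2, on the same kind of place. Because a 2.5-fold higher number from compound 1 to compound 2 (0.40 log units; beyond the scatter) was modest, a similar step is expected for compound 4, namely a 2.1-fold higher number from compound 3 to compound 4 (0.32 log units; beyond the scatter). Compound 4 is therefore estimated at 90000 nM, with a likely range from 35000 nM to 220000 nM.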

Compound 4, half-maximal inhibitory concentration: 53000 nM
Beside the measured number, compound 4's estimate is 1.7-fold (0.23 log units) above it, and the stated range covers the measured number.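

In this assay, among the compounds shown here, chloro in place of hydrogen gave a 1.2-fold higher number from compound 3 to compound 4 (0.09 log units; within the scatter), and 4-chlorophenyl in place of 3,4-dimethoxyphenyl gave a 1.4-fold higher number from compound 2 to compound 4 (0.14 log units; within the scatter), but with only two cores for each change, this neither proves that either change carries over unaltered nor shows that its size depends on the core. The chloro change shows no difference between the two cores that stands clear of the scatter: the same change on two cores in this assay, a 2.5-fold higher number (0.40 log units; beyond the scatter) from compound 1 to compound 2 and a 1.2-fold higher number (0.09 log units; within the scatter) from compound 3 to compound 4, 2.1-fold (0.32 log units) apart, within the scatter of two such steps. The same holds for the change of the aryl group: the same change on two cores in this assay, a 2.8-fold higher number (0.45 log units; beyond the scatter) from compound 1 to compound 3 and a 1.4-fold higher number (0.14 log units; within the scatter) from compound 2 to compound 4, 2.1-fold (0.32 log units) apart, within the scatter of two such steps.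

The compounds shown leave open how an amine or a carboxylic acid in place of chloro would read in this assay. They also leave open whether either change would hold on a third core.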